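Monobromo analogue in the flavone-benzoxazine series

This account rests on a few compounds, and the source may have more. Where it says the series, first, only, none or still open, it means among the compounds named here.

Measured so far:
- compound 1 `O=c1cc(-c2ccccc2)oc2ccc(N3COc4c(Br)cc(Br)cc4C3)cc12`: 6.54%
- compound 2 `O=c1cc(-c2ccccc2)oc2ccc(N3COc4ccccc4C3)cc12`: 8.7%

In a functional assay on MCF7 cells (Homo sapiens) for inhibition, read by MTT assay, with a stated time of 48 h, tested at 7.5 ug/mL (on this read-out lower numbers stand for less inhibition of growth and higher numbers for more inhibition of growth at the one concentration tested), compound 1 gives 6.54% and compound 2 gives 8.7%; the two numbers sit within the scatter of each other, so neither is told apart from the other. Compound 3 `O=c1cc(-c2ccccc2)oc2ccc(N3COc4c(Br)cccc4C3)cc12` differs from compound 2 by bromo in place of hydrogen on an aromatic carbon. For the measured compounds named here, no measured pair shows this single change. Since compound 1 carries two bromo groups and still lands within the scatter of compound 2, no step beyond the scatter is expected in this assay. For compound 3 the expected step is a number 1.2 percentage points lower from compound 2 to compound 3 (within the scatter). Compound 3 is thus estimated at 7.5%, within 2% to 14%.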

Compound 3, percent growth inhibition at one concentration: "not active" (no number reported)
For compound 3 the study gives words and no number; the estimate stays without a comparison.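

For the compounds shown here, compound 3 is reported in words only in this assay, so no step from compound 2 to compound 3 can be read. The compounds shown leave open what a single bromo in place of hydrogen does to growth inhibition. No supporting data bear on this result.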